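The compounds below may be only part of what the source reports. "The series", "measured", "known", "first", "only" and "open" are said of these compounds alone.

Measured so far in a functional assay on Daudi cells (Homo sapiens) for antiproliferative activity; on this read-out higher numbers stand for weaker inhibition and lower numbers for stronger inhibition:
Compound 1, `Nc1ncnc2c1c(-c1cc3ccccc3o1)cn2[C@H]1CCN(C[C@H]2CO2)C1`; compound 1 gives 4210 nM
Compound 2, `Nc1ncnc2c1c(-c1ccc(NC(=O)c3ccccc3)cc1)cn2[C@H]1CCN(C[C@@H]2CO2)C1`; compound 2 gives 3180 nM
Compound 3, `CC(C)(C)c1ccc(COc2ccc(-c3cn([C@H]4CCN(C[C@@H]5CO5)C4)c4ncnc(N)c34)cc2)cc1`; compound 3 gives 6970 nM

Compound 3 carries the highest number of the three in this assay. Among the compounds with values here, its gap to compound 1 lies within the scatter, so no order between those two is claimed; its gap to compound 2 lies beyond it, and that pair is the one single-site step measured, a 2.2-fold higher number from compound 2 to compound 3 (0.34 log units; beyond the scatter), a modest loss.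

Compound 4, `CC(C)(C)c1ccc(Oc2ccc(-c3cn([C@H]4CCN(C[C@@H]5CO5)C4)c4ncnc(N)c34)cc2)cc1`, differs from compound 3 in one place: 4-(tert-butyl)phenyl in place of 4-(tert-butyl)benzyl on an oxygen on an aromatic ring. Cut one bond further out, this reads (4-(tert-butyl)benzyl)oxy to 4-(tert-butyl)phenoxy.

Within the data shown here, no measured step bears directly on this change. The step from compound 2 to compound 3 exchanges the whole group on the aromatic carbon and says nothing about exchanging 4-(tert-butyl)benzyl for 4-(tert-butyl)phenyl on the oxygen; compound 1 and compound 2 offer no pairing of that kind either. The series therefore gives no basis for a direction, and the expectation in this assay is no step beyond the scatter, a 1.1-fold lower number from compound 3 to compound 4 (0.03 log units; within the scatter), estimated with a wide range. Compound 4 is expected to give about 6500 nM, between 2000 nM and 20000 nM.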

Compound 4, half-maximal inhibitory concentration: 6490 nM
The estimate for compound 4 lay 1.0-fold (0.00 log units) above the measured number, within the range that was stated.
By their numbers in this assay, from the lowest: compounds 2, 1, 4 and 3 (each within the scatter of the next, the first and the last beyond it).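

In this assay, exchanging 4-(tert-butyl)benzyl for 4-(tert-butyl)phenyl on the oxygen gives a 1.1-fold lower number from compound 3 to compound 4 (0.03 log units; within the scatter), so this change separates the two groups by no measurable amount at this position. The comparison with benzamido on the aromatic carbon now has a second member, with a 2.0-fold higher number from compound 2 to compound 4 (0.31 log units; beyond the scatter) as a modest step in the same direction as a 2.2-fold higher number from compound 2 to compound 3 (0.34 log units; beyond the scatter), and both 4-(tert-butyl)phenoxy and (4-(tert-butyl)benzyl)oxy therefore give higher numbers than benzamido in this small set. No accompanying data bear on the cause of these steps.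

Still open, from the compounds shown here alone, is whether the indifference to the exchange on the oxygen holds only for groups ending in 4-(tert-butyl)phenyl, or also for an unsubstituted phenyl, a longer alkyl chain or a group carrying an amine or a carboxylic acid. Also open, going by these compounds, is which part of benzamido goes with the lower number in compound 2, a question that a reversed amide or a urea at the same aromatic carbon could address.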